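This account rests on a few compounds, and the source may have more. Where it says the series, first, only, none or still open, it means among the compounds named here.

Working notes on the series. Of the compounds shown here, three sharing one core have been measured in an assay on Sf21 cells for inhibition of high affinity nerve growth factor receptor (Homo sapiens), read by HTRF, with a stated time of 30 min, in the presence of a further agent that is not named here; a higher number here means a weaker inhibitor, a lower number a stronger inhibitor. Compound 1 `CC1(C)c2[nH]nc(NC(=O)c3ccc4ncccc4c3)c2CN1Cc1cc(F)cc(F)c1` gives 180 nM, the highest of the three numbers. Compound 2 `CN(C)c1ccc(C(=O)Nc2n[nH]c3c2CN(Cc2cccc(F)c2F)C3(C)C)cc1` gives 69 nM, and compound 3 `CN1CCN(c2ccc(C(=O)Nc3n[nH]c4c3CN(Cc3cccc(F)c3F)C4(C)C)cc2)CC1` gives 17 nM. Going by the values given here, the one single-point step measured, a 4.1-fold lower number from compound 2 to compound 3 (0.61 log units; beyond the scatter), is 4-methylpiperazin-1-yl in place of dimethylamino on an aromatic carbon.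

Compound 4 `CN(C)c1cccc(C(=O)Nc2n[nH]c3c2CN(Cc2cc(F)cc(F)c2)C3(C)C)c1` is not yet measured. It differs from compound 1 by 3-(dimethylamino)phenyl in place of quinolin-6-yl on a carbonyl carbon. Among the compounds with values here, no measured step covers this exchange; compound 2 carries a dimethylamino-bearing ring with a different benzyl group, so its value and that of compound 1 can only be set side by side. For compound 4 the expectation is a step of a 1.4-fold higher number from compound 1 to compound 4 (0.14 log units; within the scatter), within or near the scatter. Compound 4 is therefore estimated at 250 nM, between 80 nM and 800 nM.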

Compound 4, half-maximal inhibitory concentration: 270 nM
The estimate for compound 4 lay 1.1-fold (0.03 log units) below the measured number; low and high end bracket the measured number.
By their numbers in this assay, from the lowest: compound 3; then compound 2; then compounds 1 and 4 (each within the scatter of the next).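

The exchange on this carbonyl carbon gives a 1.5-fold higher number from compound 1 to compound 4 (0.18 log units; within the scatter) in this assay. With the benzyl group of compound 1 kept, a single carbon-only aromatic ring bearing dimethylamino therefore reads the same as the two-ring quinolin-6-yl, within the scatter. No measurement here gives a reason for this equivalence.

Going by these compounds, it remains open whether the gain seen with 4-methylpiperazin-1-yl in compound 3 carries over to the benzyl group of compound 4. Also open, on these data alone, is how a morpholine or a carboxylic acid on the same ring would read.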